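Compound 4 and a series without a number

The source may hold more compounds than are shown below. What is called first, only, known or untested is meant among the compounds shown, and "the series" means these compounds.

Measured so far in a functional assay on A-431 cells (Homo sapiens); on this read-out higher numbers stand for an effect only at larger amounts of compound and lower numbers for an effect already at smaller amounts:

compound 1 `COc1cc(Nc2ncccc2-c2nc(Nc3cc(OC)ccc3OC)n[nH]2)cc(OC)c1` reads > 10000 nM (a limit of the assay)
compound 2 `COc1cc(Nc2ncccc2-c2n[nH]c(Nc3ccc(N(C)C)cc3)n2)cc(OC)c1` reads "not determined" (no result reported)
compound 3 `COc1cc(Nc2ncccc2-c2n[nH]c(Nc3cc(Cl)cc(Cl)c3)n2)cc(OC)c1` reads "not determined" (no result reported)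

Compound 3 has no single number to stand on, since no result was reported for it. Its neighbours offer little more: compound 2 also has no result, and the only other entry is a limit. Compound 1 sits at > 10000 nM, and this is a limit and not a number. The whole numerical picture is therefore (the limit of > 10000 nM in this assay, at which 1 of the 3 values shown sits).

The next compound to be tested is compound 4 `COc1cc(Nc2ncccc2-c2n[nH]c(Nc3ccc4c(c3)OCCO4)n2)cc(OC)c1`. The change is 2,3-dihydro-1,4-benzodioxin-6-yl in place of 3,5-dichlorophenyl on a nitrogen on an aromatic ring. In words, 2,3-dihydro-1,4-benzodioxin-6-yl takes the place of 3,5-dichlorophenyl on a nitrogen on an aromatic ring.

Among the compounds with values here, no measured step shows what a change of this kind does, and compound 3 offers no starting value. The expectation in this assay is therefore a modest one, with no large move towards smaller amounts. It rests on compound 1 alone, at its limit of > 10000 nM, so compound 4 is expected to stay in that region. The estimate for compound 4 is 8000 nM, with an expected range from 1500 nM to 20000 nM.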

Compound 4, half-maximal effective concentration: 117 nM
Beside the measured number, compound 4's estimate is 68-fold (1.83 log units) above it; the whole stated range lies above it.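

Within the data shown here, compound 3 reads "not determined" (no result reported) in this assay, so no step from it to compound 4 can be read. Compound 1 offers only a limit: the limit of > 10000 nM in this assay, at which 1 of the 4 values shown sits.

The compounds shown leave open how much the 2,3-dihydro-1,4-benzodioxin-6-yl group itself contributes to the value of compound 4.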